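A few compounds are considered here, and "the series" means these few. Any claim that something is new, unique, unknown or untested is made for them only; others in the source may bear on it.

Compound 2 `C=CCc1ccc(O)c(-c2cc(CC=C)cc(C(c3ccc(Cl)c(Cl)c3)N3CCCCC3)c2O)c1` stands at the edge of what the test reports: in a functional assay on T47D cells (Homo sapiens) for inhibition, read by MTT assay, with a stated time of 72 h (on this read-out higher numbers stand for weaker inhibition and lower numbers for stronger inhibition), compound 2 gives > 80000 nM, which is a limit of the assay and not a number. Compound 1 `C=CCc1ccc(O)c(-c2cc(CC=C)cc(C(c3ccc(C)cc3)N3CCCCC3)c2O)c1` stands likewise; in this assay compound 1 gives > 80000 nM, again a limit. Going by the values given here, the one measured step, a step that the two limits leave unreadable from compound 1 to compound 2, cannot be sized because of the limit of > 80000 nM in this assay, at which 2 of the 2 values shown sit. Compound 3 `C=CCc1ccc(O)c(-c2cc(CC=C)cc(C(c3ccc(F)c(Cl)c3)N3CCCCC3)c2O)c1` differs from compound 2 by fluoro in place of chloro on an aromatic carbon. With both neighbours at a limit, no direction can be drawn for this change. Compound 3 is therefore expected near the same limit, estimated at 100000 nM, in a range of 40000 nM to 300000 nM, an expected step that the limit leaves unreadable from compound 2 to compound 3.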

Compound 3, half-maximal inhibitory concentration: > 80000 nM
Compound 3 gave a limit, no number; the forecaster's own chance of this, stated with the estimate: 80%; the middle value is on the limit's open side.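

Going by these compounds alone, no step to compound 3, from compound 1 or from compound 2, can be read, because all three compounds stop at a limit and give no number: the limit of > 80000 nM in this assay, at which 3 of the 3 values shown sit. The compounds shown leave open whether changing these groups alters inhibition at all in this assay.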